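Exchanging the side chain of compound 3

This account rests on a few compounds, and the source may have more. Where it says the series, first, only, none or still open, it means among the compounds named here.

Of the compounds shown here, three sharing one core have been measured in an assay on isolated protein for binding affinity to 5-hydroxytryptamine receptor 3A (Homo sapiens); a higher number here means a weaker inhibitor, a lower number a stronger inhibitor. Compound 1 `CCc1nc2c(C(=O)NCC3CCN(CC(O)CN4CCN(S(C)(=O)=O)CC4)CC3)cccc2[nH]1` gives 79400 nM. Compound 2 `CC(C)(C)c1nc2c(C(=O)NCC3CCN(CC(O)CN4CCN(S(C)(=O)=O)CC4)CC3)cccc2[nH]1` differs from compound 1 only in the group on the aromatic carbon; compound 2 gives 39800 nM, and the change is a 2.0-fold lower number from compound 1 to compound 2 (0.30 log units; within the scatter). Compound 3 `COC(=O)N1CCN(CCN2CCC(CNC(=O)c3cccc4[nH]c(C(C)C)nc34)CC2)CC1` gives 79400 nM, level with compound 1 at the digits shown; together they carry the highest numbers of the three, while the number for compound 2 stands within the scatter of that for compound 3, so no ordering among the three can be claimed.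

Compound 4 `CC(=O)N(C)CC(O)CN1CCC(CNC(=O)c2cccc3[nH]c(C(C)C)nc23)CC1` differs from compound 3 in the chain carried by the ring nitrogen: 2-(acetyl(methyl)amino)-1-hydroxyethyl in place of (4-(methoxycarbonyl)piperazin-1-yl)methyl on a saturated chain carbon bound to an amine nitrogen in a ring. Going by the values given here, no measured step touches this part of the molecule; the only measured step, a 2.0-fold lower number from compound 1 to compound 2 (0.30 log units; within the scatter), concerns the group on the aromatic carbon and stayed within the scatter. Compounds 1 and 3, which carry different side chains at that place but also differ elsewhere, show the same number, which gives no sign that this region moves the read-out. Compound 4 is therefore expected to stay close to compound 3, with a 1.1-fold lower number from compound 3 to compound 4 (0.05 log units; within the scatter) as the estimated step, meaning no change beyond the scatter. The estimate for compound 4 in this assay is 70000 nM, with a range from 20000 nM to 250000 nM.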

Compound 4, inhibition constant: 63100 nM
For compound 4 the middle estimate is 1.1-fold (0.05 log units) above the measured one; low and high end bracket the measured number.
By their numbers in this assay, from the lowest: compounds 2, 4, 1 and 3 (each within the scatter of the next).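

Going by these compounds alone, compound 3 and compound 4 give the first direct reading of a change on a saturated chain carbon bound to an amine nitrogen in a ring. In this assay, the exchange gives a 1.3-fold lower number from compound 3 to compound 4 (0.10 log units; within the scatter) and stays within the scatter. The two chains differ markedly: (4-(methoxycarbonyl)piperazin-1-yl)methyl has a six-membered non-aromatic ring and 0 hydrogen-bond donors, while 2-(acetyl(methyl)amino)-1-hydroxyethyl has no ring and 1 hydrogen-bond donor, so for this pair, replacing the ring-bearing chain with the open one leaves no change that can be told from scatter. No supporting measurement is available to explain this result.

The compounds shown leave open whether a chain ending in a primary amine or a carboxylic acid, or a longer chain, would move the number beyond the scatter at this place. They also leave open whether the same exchange would give so small a step with a tert-butyl group on the aromatic carbon of the shared core, as neither compound in this pair carries that group.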